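Cytotoxicity notes: replacing the group on the amine nitrogen

A few compounds are considered here, and "the series" means these few. Any claim that something is new, unique, unknown or untested is made for them only; others in the source may bear on it.

Compound 1 `CS(=O)(=O)Oc1c(C(=O)NCc2ccc(F)cc2)nc(Br)c2cccnc12`: > 20000 nM (a limit)
Compound 2 `Nc1ccc(Nc2c(C(=O)NCc3ccc(F)cc3)nc(Br)c3cccnc23)cc1`: 10000 nM

Going by the values given here, in a functional assay on HCT-116 cells (Homo sapiens) for cytotoxicity, read by MTT assay, with a stated time of 72 h (on this read-out higher numbers stand for weaker inhibition and lower numbers for stronger inhibition), compound 2 gives 10000 nM, the only exact number so far. Compound 1 stands at a limit: the limit of > 20000 nM in this assay, at which 1 of the 2 values shown sits.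

Compound 3 `O=C(NCc1ccc(F)cc1)c1nc(Br)c2cccnc2c1NCc1ccc(F)cc1` differs from compound 2 as follows: 4-fluorobenzyl in place of 4-aminophenyl on a nitrogen on an aromatic ring.

Among the compounds with values here, the sole measured step, an at least 2.0-fold lower number from compound 1 to compound 2 (0.30 log units; that floor lies within the scatter), concerns a change on an aromatic carbon, so it gives no size for this change on the nitrogen. With only the value of compound 2 at 10000 nM as an anchor, no shift beyond the scatter is expected in this assay. The estimated step is a 1.2-fold higher number from compound 2 to compound 3 (0.08 log units; within the scatter). Compound 3 is expected at 12000 nM, with an estimated range of 4000 nM to 20000 nM.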

Compound 3, half-maximal inhibitory concentration: > 20000 nM
Compound 3: no number, only a limit; the forecaster's own chance of this, stated with the estimate: 30%; middle value at least 1.6-fold (0.22 log units) away from the limit.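

Going by these compounds alone, on the nitrogen, 4-fluorobenzyl in place of 4-aminophenyl gives the first reading for a change at this place in this assay: an at least 2.0-fold higher number from compound 2 to compound 3 (0.30 log units; that floor lies within the scatter). Compound 3 gives > 20000 nM, which is a limit and not a number. Of the compounds shown, only compound 2 has an exact value, and the others sit at the top of the range: the limit of > 20000 nM in this assay, at which 2 of the 3 values shown sit.

The step from compound 1 to compound 3 cannot be read: both values are limits. From the compounds shown here alone, what 4-aminobenzyl or a plain amine on this nitrogen would give remains open.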